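Adding a Hydroxymethyl Group to a Furan Amide

The source may hold more compounds than are shown below. What is called first, only, known or untested is meant among the compounds shown, and "the series" means these compounds.

Of the compounds shown here, three have been measured in an assay on isolated protein for inhibition of sphingosine 1-phosphate receptor 5 (Homo sapiens), tested at 25 uM; on this read-out lower numbers stand for less inhibition and higher numbers for more inhibition at the one concentration tested (going by the name of the read-out). Compound 1 `CCc1cccc(C)c1NC(=O)c1ccc(-c2cc(Cl)ccc2Cl)o1` gives 50%. Compound 2 `Cc1ccsc1-c1ccc(C(=O)Nc2c(C)cccc2C)o1` gives 40%, and compound 3 `COc1cc(C)c(NC(=O)c2ccc(-c3cc(Cl)ccc3Cl)o2)c(C)c1` gives 40%. The numbers for compound 2 and compound 3 are the same at the digits shown, and the number for compound 1 differs from them only within the usual scatter of this kind of measurement, so no ranking among the three can be drawn.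

Compound 4 `Cc1ccsc1-c1ccc(C(=O)Nc2c(C)cc(CO)cc2C)o1` has not yet been measured. It differs from compound 2 in one place: hydroxymethyl in place of hydrogen on an aromatic carbon. Among the compounds with values here, no pair of measured compounds shows the effect of such a change, so nothing here points in either direction. The step of a number 5 percentage points lower from compound 2 to compound 4 (within the scatter) is therefore expected to stay within the scatter. Compound 4 is estimated to give 35%, with a range from 15% to 55%.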

Compound 4, a percentage reported as inhibition, at one concentration (the size of the read-out at that concentration, not a potency): "not active" (no number reported)
The entry for compound 4 holds no number, and the estimate cannot be compared.
By their numbers in this assay, from the lowest: compounds 2, 3 and 1 (each within the scatter of the next).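

Within the data shown here, compound 4 carries no number in this assay, so no step from compound 2 to it can be read. As far as these compounds go, whether hydroxymethyl in place of hydrogen changes the inhibition stays open, and no other evidence bears on this result.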